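Replacing the nitro group of compound 1 with hydrogen

A few compounds are considered here, and "the series" means these few. Any claim that something is new, unique, unknown or untested is made for them only; others in the source may bear on it.

Going by the values given here, in an ADME assay on HMEC-1 cells (Homo sapiens) for cytotoxicity, read by MTT assay, with a stated time of 72 h (on this read-out lower numbers stand for stronger inhibition and higher numbers for weaker inhibition), compound 1 `N[C@H](C(=O)NCc1ccc([N+](=O)[O-])cc1)[C@@H]1CC(Br)=NO1` gives 36100 nM, the only number available. In this assay, compound 2 `N[C@H](CSCc1ccccc1)[C@@H]1CC(Br)=NO1` has the entry "not determined" (no result reported). Compound 3 `N[C@H](CSCc1ccccc1)[C@H]1CC(Br)=NO1` has the entry "not determined" (no result reported). The relation between these two is the fact that compounds 2 and 3 differ only in the configuration as drawn, and it offers no measured comparison.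

Compound 4 `N[C@H](C(=O)NCc1ccccc1)[C@@H]1CC(Br)=NO1` keeps the core of compound 1 and has hydrogen in place of nitro on an aromatic carbon, para to a large group (hydrogen in place of nitro on an aromatic carbon). Among the compounds with values here, no measured step bears on this change, so only a small shift toward weaker inhibition, within the usual scatter, is expected. The estimated step is a 1.2-fold higher number from compound 1 to compound 4 (0.10 log units; within the scatter). For compound 4, the expected value is 45000 nM, with an estimated range from 16000 nM to 120000 nM.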

Compound 4, half-maximal inhibitory concentration: 14900 nM
Beside the measured number, compound 4's estimate is 3.0-fold (0.48 log units) above it, and the stated range ends above it.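

In this assay hydrogen in place of nitro gives a 2.4-fold lower number from compound 1 to compound 4 (0.38 log units; beyond the scatter) and so marks a modest move toward stronger inhibition. Going by these compounds alone, this is the first measured comparison at this aromatic carbon, para to a large group, and it shows that the read-out responds to a change at this place. Nothing available explains the size or direction of this shift.

The compounds shown leave open how an amine or a carboxylic acid on that same aromatic carbon would read. They also leave open whether the shift would carry over to the benzylthio side chain of compound 2 and compound 3.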